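The compounds below may be only part of what the source reports. "The series", "measured", "known", "first", "only" and "open" are said of these compounds alone.

Measured so far:
- compound 1, `NC(=O)c1cc(-c2ccc(-c3ccc(Cl)cc3Cl)cc2)n(-c2ccccn2)n1`: > 100000 nM
- compound 2, `O=C(O)c1cc(-c2ccc(-c3ccc(F)c(Cl)c3)cc2)n(-c2ccc(Cl)cc2Cl)n1`: 20900 nM
- compound 3, `O=C(O)Cn1nc(C(=O)O)cc1-c1ccc(-c2ccc(Cl)cc2Cl)cc1`: 100000 nM

In an assay on isolated protein for inhibition of methionine--tRNA ligase, cytoplasmic (Homo sapiens) (a higher number here means a weaker inhibitor, a lower number a stronger inhibitor), compound 1 gives only a limit, > 100000 nM, and not a number; this is the limit described by the limit of > 100000 nM in this assay, at which 1 of the 3 values shown sits. Among the two numbers that remain, compound 3 holds the higher one, 100000 nM, while compound 2 sits lower at 20900 nM, a gap beyond the scatter, so compound 3 is the weaker of the two measured inhibitors.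

The next compound, compound 4, `CCn1nc(C(=O)O)cc1-c1ccc(-c2ccc(Cl)cc2Cl)cc1`, is not yet measured in this assay. It differs from compound 3 in one place: methyl in place of carboxy on a saturated chain carbon bound to an aromatic nitrogen. For the measured compounds named here, no measured pair shows this change, so the expected direction rests only on compound 3 itself. The step of a 1.7-fold lower number from compound 3 to compound 4 (0.22 log units; within the scatter) is estimated to be a small move toward stronger inhibition, barely beyond the scatter. Compound 4 is therefore expected to give about 60000 nM in this assay, with a likely range from 15000 nM to 150000 nM.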

Compound 4, half-maximal inhibitory concentration: 46400 nM
For compound 4 the middle estimate is 1.3-fold (0.11 log units) above the measured one, within the range that was stated.
By their numbers in this assay, from the lowest: compound 2; then compound 4; then compound 3.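

In this assay, for the compounds shown here, this is the first single change that can be read: putting methyl in place of carboxy, which turns carboxymethyl into ethyl on the aromatic nitrogen, gives a 2.2-fold lower number from compound 3 to compound 4 (0.33 log units; beyond the scatter) and so a modest gain in inhibition. The carboxy group at this position is therefore not needed for the weak inhibition seen here, and losing it, along with its hydrogen-bond donor and acceptor, costs no strength. Nothing measured here explains why the number moves in this direction.

As far as these compounds go, whether a longer chain such as propyl, or an amine such as aminoethyl, at this position would strengthen inhibition further remains open. Also open, from the compounds shown here alone, is whether the other carboxylic acid, which compound 3 and compound 4 share, could give way to an ester or a tetrazole.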